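Adding a second chloro to the aryl ring of compound 2

The compounds below may be only part of what the source reports. "The series", "measured", "known", "first", "only" and "open" are said of these compounds alone.

The series shares a dimethylpyrrole carboxylic acid core carrying an aryl ring on nitrogen. Compound 1 `Cc1cc(C(=O)O)c(C)n1-c1ccccc1Cl` gives 2300 nM in an assay on cells for inhibition of Palmitoleoyl-protein carboxylesterase NOTUM variant C330S (Homo sapiens), read by fluorescence, with a stated time of 40 min; on this read-out higher numbers stand for weaker inhibition and lower numbers for stronger inhibition. Compound 2 `Cc1cc(C(=O)O)c(C)n1-c1cccc(Cl)c1` gives 430 nM in this assay, the lowest of the three numbers shown, and compound 3 `Cc1cc(C(=O)O)c(C)n1-c1cccc(C#N)c1` gives 3100 nM. The one step among these that changes a single place, a 7.2-fold higher number from compound 2 to compound 3 (0.86 log units; beyond the scatter), comes from cyano in place of chloro on an aromatic carbon and is the larger of the two gaps that separate compound 2 from its neighbours; the gap to compound 1, which carries its chloro at a different position, is somewhat smaller but also lies beyond the scatter.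

Compound 4 `Cc1cc(C(=O)O)c(C)n1-c1cc(Cl)ccc1Cl` differs from compound 2 by chloro in place of hydrogen on an aromatic carbon, the new chloro sitting ortho to a large group and para to the chloro group already present. For the measured compounds named here, no measured step adds a group while leaving the existing chloro in place, so the expectation rests on the values of compound 1 and compound 2 alone. The number for compound 4 in this assay is expected to move by a 1.7-fold higher number from compound 2 to compound 4 (0.24 log units; within the scatter), a step that may or may not exceed the scatter. Compound 4 is therefore estimated at 750 nM, with a range from 250 nM to 2200 nM.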

Compound 4, half-maximal inhibitory concentration: 1700 nM
For compound 4 the middle estimate is 2.3-fold (0.36 log units) below the measured one, and the stated range covers the measured number.
By their numbers in this assay, from the lowest: compound 2; then compounds 4, 1 and 3 (each within the scatter of the next).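

Placed ortho to a large group and para to the chloro group already present, the new chloro does not lower the number in this assay, but gives a 4.0-fold higher number from compound 2 to compound 4 (0.60 log units; beyond the scatter), so this second chloro weakens inhibition relative to the singly substituted compound. The same kind of change read from the other neighbour gives a 1.4-fold lower number from compound 1 to compound 4 (0.13 log units; within the scatter), which lies within the scatter, so there the added chloro produces no readable change and the two compounds cannot be ordered; the effect of chloro in place of hydrogen on this ring therefore depends on which compound receives it. Nothing among the available data accounts for this difference between the two steps.

From the compounds shown here alone, it remains open whether the rise from compound 2 to compound 4 is particular to chloro or would also follow from another group on this aromatic carbon, such as fluoro, methyl, methoxy or an amine. Going by these compounds, it is also open whether a second chloro elsewhere on the ring of compound 2 would leave its number intact.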